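Methyl in place of nitro on a weakly active core

A few compounds are considered here, and "the series" means these few. Any claim that something is new, unique, unknown or untested is made for them only; others in the source may bear on it.

Compound 1, `O=C(O)C1=Cc2ccccc2OC1(OCc1cc(-c2ccc([N+](=O)[O-])cc2)no1)C(F)(F)F`, gives in a functional assay on HeLa cells (Homo sapiens) for inhibition, read by MTT assay, with a stated time of 24 h (a higher number here means a weaker inhibitor, a lower number a stronger inhibitor), only a limit: > 150000 nM.
Compound 2, `CCOC(=O)C1=Cc2ccccc2OC1(OCc1cc(-c2ccc([N+](=O)[O-])cc2)no1)C(F)(F)F`, gives in this assay only a limit: > 150000 nM.
Compound 3, `CCOC(=O)C1=Cc2ccccc2OC1(OCc1cn(-c2cccc(OC)c2)nn1)C(F)(F)F`, gives in this assay only a limit: > 150000 nM.

All three measured compounds sit at the same limit in this assay, as the limit of > 150000 nM in this assay, at which 3 of the 3 values shown sit, records; none of them reached a measurable number. Among the compounds with values here, the single step between compounds that differ in one place, a step that the two limits leave unreadable from compound 1 to compound 2, therefore cannot be read, since both ends are limits. Compound 1 thus stands at the limit, with no measured neighbour that would place it higher or lower.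

Compound 4, `Cc1ccc(-c2cc(COC3(C(F)(F)F)Oc4ccccc4C=C3C(=O)O)on2)cc1`, differs from compound 1 in one place: methyl in place of nitro on an aromatic carbon. No measured step touches this part of the structure, so nothing among the shown data speaks for a change in either direction, and the only evidence is that every measured compound, compound 1, compound 2 and compound 3 alike, fell at the limit.

On that basis compound 4 is expected to behave like compound 1, with the estimated step that the limit leaves unreadable from compound 1 to compound 4 amounting to nothing beyond the scatter. The estimate for compound 4 is 250000 nM, in a range from 100000 nM to 1000000 nM, most likely again reported only as a limit.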

Compound 4, half-maximal inhibitory concentration: 33400 nM
The estimate for compound 4 lay 7.5-fold (0.87 log units) above the measured number; measured number below the stated range.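

Within the data shown here, replacing the 4-nitrophenyl of compound 1 with 4-methylphenyl gives an at least 4.4-fold lower number from compound 1 to compound 4 (0.65 log units; beyond the scatter) in this assay, and this is the first change whose effect can be read at all. It shows that this position, on an aromatic carbon para to a large group, matters for the result, and that a small swap there can move a compound on the shared core from a limit to a real number. Compound 4 gives 33400 nM. That number stands alone, and the other compounds remain at a single ceiling: the limit of > 150000 nM in this assay, at which 3 of the 4 values shown sit.

The true size of the step stays unknown, since compound 1 has only a limit, and no measured property of the nitro or methyl group is shown that could explain the gain or tell whether it comes from adding methyl or from losing nitro. Going by these compounds, it also remains open whether a chlorine atom, an amine or a longer chain such as ethyl at this same position would give a lower or a higher number than methyl, and whether the gain would carry over to the ethyl ester.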